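Swapping the amide aryl group on compound 1

The source may hold more compounds than are shown below. What is called first, only, known or untested is meant among the compounds shown, and "the series" means these compounds.

Measured compounds:
- Compound 1 `Cc1cccc(Cl)c1NC(=O)CN1CCN(c2nnc(Cc3ccncc3)c3ccccc23)CC1`: 2670 nM
- Compound 2 `COc1ccc(NC(=O)CN2CCN(c3nnc(Cc4ccccc4)c4ccccc34)CC2)cc1OC`: 32200 nM
- Compound 3 `Cc1ccc(NC(=O)CN2CCN(c3nnc(Cc4ccccc4)c4ccccc34)CC2)c(C)c1`: 181000 nM

In a functional assay on MDA-MB-231 cells (Homo sapiens) for cytotoxicity, read by MTT assay, with a stated time of 72 h (a lower number here means a stronger inhibitor, a higher number a weaker inhibitor), compound 1 gives the lowest number of the three, and its steps to compound 2 and to compound 3 are both beyond the scatter, so it is the strongest inhibitor shown. Compound 4 `O=C(CN1CCN(c2nnc(Cc3ccncc3)c3ccccc23)CC1)Nc1c(F)cccc1F` has not been measured. It differs from compound 1 in one place: 2,6-difluorophenyl in place of 2-chloro-6-methylphenyl on an amide-type nitrogen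

Within the data shown here, only one measured step changes the group on the amide-type nitrogen, a 5.6-fold higher number from compound 2 to compound 3 (0.75 log units; beyond the scatter), and it sits on a core that carries a benzyl rather than a pyridinylmethyl group, so it does not directly bear on this step; it shows only that such a swap can move the number modestly. The change to compound 4 keeps the same place and size of group, so a small shift is expected, a 1.5-fold higher number from compound 1 to compound 4 (0.18 log units; within the scatter), with no firm direction. Compound 4 is therefore estimated at 4000 nM, within 1000 nM to 16000 nM.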

Compound 4, half-maximal inhibitory concentration: 1900 nM
The estimate for compound 4 lay 2.1-fold (0.32 log units) above the measured number, and the stated range covers the measured number.
By their numbers in this assay, from the lowest: compounds 4 and 1 (each within the scatter of the next); then compound 2; then compound 3.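

In this assay, among these compounds, the first measured swap on the amide-type nitrogen of the core of compound 1 gives a 1.4-fold lower number from compound 1 to compound 4 (0.15 log units; within the scatter), so 2,6-difluorophenyl and 2-chloro-6-methylphenyl cannot be told apart in this assay. Among the compounds shown here, two fluorine atoms can thus stand in for the chlorine and methyl of the leaving group without a change beyond the scatter, on the core with the pyridinylmethyl group, whereas the only earlier swap at this place, on the benzyl core, went beyond the scatter. No measurement here offers a reason for this result.

The compounds shown leave open what a group of a different kind would do on this nitrogen, such as unsubstituted phenyl, cyclohexyl, or a phenyl ring carrying a carboxylic acid or an amine. They also leave open whether 2,6-difluorophenyl would give a similar number on the benzyl core.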